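A few compounds are considered here, and "the series" means these few. Any claim that something is new, unique, unknown or untested is made for them only; others in the source may bear on it.

Working notes on the series. In a functional assay on SNB-75 cells (Homo sapiens) for inhibition, read by sulforhodamine B assay, with a stated time of 48 h (on this read-out lower numbers stand for stronger inhibition of growth and higher numbers for weaker inhibition of growth), compound 2 (`CCCCCCCCCCCC[C@@H](O)[C@H]1CC[C@H]([C@H](O)CCCCCCCCCCNCc2ccnn2C)O1`) gives 2000 nM, the lowest number of the three measured. Compound 1 (`CCCCCCCCCCCC[C@@H](O)[C@H]1CC[C@H]([C@H](O)CCCCCCCCCCN(C)C(=O)c2ccnn2C)O1`) gives 15800 nM, and compound 3 (`CCCCCCCCCCCC[C@@H](O)[C@H]1CC[C@H]([C@H](O)CCCCCCCCCCC(=O)Nc2ccnn2C)O1`) gives 100000 nM.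

The next comparison is with compound 4 (`CCCCCCCCCCCC[C@@H](O)[C@H]1CC[C@H]([C@H](O)CCCCCCCCCCOC(=O)c2ccnn2C)O1`), which keeps the shared core of compound 2. The change is ((1-methyl-1H-pyrazol-5-yl)carbonyl)oxy in place of ((1-methyl-1H-pyrazol-5-yl)methyl)amino on a saturated chain carbon, ten or more bonds along the chain from an oxygen on a saturated carbon and a saturated ring carbon. In words, ((1-methyl-1H-pyrazol-5-yl)carbonyl)oxy replaces ((1-methyl-1H-pyrazol-5-yl)methyl)amino on a saturated chain carbon.

For the measured compounds named here, two measured steps bear on this change. The modest 7.9-fold lower number from compound 1 to compound 2 (0.90 log units; beyond the scatter) removes a carbonyl-bearing group in favour of the group compound 2 carries, and the large 50-fold higher number from compound 2 to compound 3 (1.70 log units; beyond the scatter) goes the other way. Among these three compounds, both carbonyl-bearing linkers sit at higher numbers than compound 2, and none goes against this, though three compounds make a thin basis. Compound 1 also carries the (1-methyl-1H-pyrazol-5-yl)carbonyl unit, so it is the closer guide, and no ester has been measured yet.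

A modest-to-large rise in this assay is therefore expected, beyond the scatter. The expected change is a 7.5-fold higher number from compound 2 to compound 4 (0.88 log units; beyond the scatter). For compound 4 the estimated value is 15000 nM, with an expected range of 4000 nM to 60000 nM.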

Compound 4, concentration for 50% growth inhibition: 100000 nM
Beside the measured number, compound 4's estimate is 6.7-fold (0.82 log units) below it; measured number outside the range, above it.
By their numbers in this assay, from the lowest: compound 2; then compound 1; then compounds 3 and 4 (each within the scatter of the next).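

In this assay, replacing ((1-methyl-1H-pyrazol-5-yl)methyl)amino with the ester linker gives a 50-fold higher number from compound 2 to compound 4 (1.70 log units; beyond the scatter), and the ester also separates from the methylated amide, with a 6.3-fold higher number from compound 1 to compound 4 (0.80 log units; beyond the scatter), so the (1-methyl-1H-pyrazol-5-yl)carbonyl unit does not by itself set the number at this position. The ester and the (1-methyl-1H-pyrazol-5-yl)carbamoyl linker cannot be told apart here, with no change at the digits printed from compound 3 to compound 4 (within the scatter), and all three carbonyl-bearing linkers now sit at higher numbers than the amine linker of compound 2, with no compound among these four going against this. Nothing available explains these differences.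

Still open, from the compounds shown here alone, is whether a tertiary amine carrying an N-methyl group, or an ether oxygen in place of the amine nitrogen, would stay close to compound 2 on this saturated chain. Also open, going by these compounds, is whether the ((1-methyl-1H-pyrazol-5-yl)methyl)amino result holds with a longer chain or with a phenyl ring in place of the 1-methyl-1H-pyrazol-5-yl ring.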